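The source may report more compounds than this note shows. Statements on the series, on what has been measured and on what is new or still open speak of the compounds shown alone.

Compound 1 `O=C(O)c1cc(N2C(=O)C3=C(CCCC3)C2=O)c(F)cc1Cl` gives 759 nM in a functional assay on the whole organism with Scenedesmus acutus as the target; a lower number here means a stronger inhibitor, a higher number a weaker inhibitor. Compound 2 `O=C(O)c1cc(N2C(=O)C3=C(CCCC3)C2=O)ccc1Cl` is reported in this assay only as a limit, > 100000 nM, which is the limit of > 100000 nM in this assay, at which 1 of the 3 values shown sits. The change between these two is hydrogen in place of fluoro on an aromatic carbon, and it produced an at least 130-fold higher number from compound 1 to compound 2 (2.11 log units; beyond the scatter). Compound 3 `CC(C)COC(=O)c1cc(N2C(=O)C3=C(CCCC3)C2=O)c(F)cc1Cl` differs from compound 1 by isobutyl in place of hydrogen on an oxygen next to a carbonyl group; in this assay compound 3 gives 33.1 nM, which is a 23-fold lower number from compound 1 to compound 3 (1.36 log units; beyond the scatter). Compound 4 `CC(C)COC(=O)c1cc(N2C(=O)C3=C(CCCC3)C2=O)ccc1Cl` has not yet been measured. For the measured compounds named here, it differs from compound 3 by hydrogen in place of fluoro on an aromatic carbon, the same kind of change as the one from compound 1 to compound 2, although there the place is para to a carboxy group whereas here it is para to an isobutoxycarbonyl group. Because an at least 130-fold higher number from compound 1 to compound 2 (2.11 log units; beyond the scatter) was so large, a comparable loss is expected, namely a 150-fold higher number from compound 3 to compound 4 (2.18 log units; beyond the scatter). Compound 4 is therefore estimated at 5000 nM, somewhere between 1000 nM and 50000 nM.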

Compound 4, half-maximal inhibitory concentration: 759 nM
Compound 4: the middle estimate sits 6.6-fold (0.82 log units) above what was measured; the whole stated range lies above it.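

In this assay, hydrogen in place of fluoro again gave a weaker inhibitor, a 23-fold higher number from compound 3 to compound 4 (1.36 log units; beyond the scatter), so the direction of the change carried from the core of compound 1 to the ester core, but its size did not: the same change on two cores in this assay, an at least 130-fold higher number (2.11 log units; beyond the scatter) from compound 1 to compound 2 and a 23-fold higher number (1.36 log units; beyond the scatter) from compound 3 to compound 4, at least 5.7-fold (0.75 log units) apart, beyond the scatter of two such steps

Isobutyl in place of hydrogen on the oxygen gave an at least 130-fold lower number from compound 2 to compound 4 (2.11 log units; beyond the scatter), and this step too differed in size from its earlier counterpart: the same change on two cores in this assay, a 23-fold lower number (1.36 log units; beyond the scatter) from compound 1 to compound 3 and an at least 130-fold lower number (2.11 log units; beyond the scatter) from compound 2 to compound 4, at least 5.7-fold (0.75 log units) apart, beyond the scatter of two such steps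

Compound 2 is only a limit, > 100000 nM, and these two pairs of steps do not show how either change would behave on any other core.

The compounds shown leave open whether a bromo or methoxy group would act as fluoro does at that place. They also leave open whether an ethyl ester or a longer chain on the oxygen would match isobutyl.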